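A swap of bromo for trifluoromethyl on an aromatic carbon

The source may report more compounds than this note shows. Statements on the series, on what has been measured and on what is new or still open speak of the compounds shown alone.

Two compounds have been measured so far in an ADME assay on HEK-293T cells (Homo sapiens) for cytotoxicity, read by MTT assay, with a stated time of 24 h (a lower number here means that less compound is tolerated, a higher number that more compound is tolerated), and they read as follows

compound 1 `O=[N+]([O-])c1ccc(S(=O)(=O)n2c(-c3cn(-c4ccccc4)nc3-c3ccc(F)cc3)nc3ccccc32)cc1` gives 189000 nM here
compound 2 `O=S(=O)(c1ccc(Br)cc1)n1c(-c2cn(-c3ccccc3)nc2-c2ccc(F)cc2)nc2ccccc21` gives 239000 nM here

Only these two numbers exist, so compound 2 has one measured neighbour. Compound 2 (239000 nM) and compound 1 (189000 nM) lie within the scatter of each other, and neither can be ranked over the other. Compound 3 `O=S(=O)(c1ccc(C(F)(F)F)cc1)n1c(-c2cn(-c3ccccc3)nc2-c2ccc(F)cc2)nc2ccccc21` has not yet been measured. It carries trifluoromethyl in place of bromo on an aromatic carbon, para to a large group (trifluoromethyl in place of bromo on an aromatic carbon). Among the measured compounds shown here, the one measured step that bears on this change is bromo in place of nitro on an aromatic carbon (a 1.3-fold higher number from compound 1 to compound 2 (0.10 log units; within the scatter)). A single step is a thin guide, but it is the only one available. On that basis, no step beyond the scatter is expected in this assay, and no direction can be favoured. The estimate therefore expects only a small step (a 1.1-fold lower number from compound 2 to compound 3 (0.06 log units; within the scatter)). For compound 3 the expected value is 210000 nM (estimated range 110000 nM to 400000 nM).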

Compound 3, half-maximal cytotoxic concentration: 241000 nM
Compound 3: the middle estimate sits 1.1-fold (0.06 log units) below what was measured; the measured number falls inside the stated range.
By their numbers in this assay, from the lowest: compounds 1, 2 and 3 (each within the scatter of the next).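

Taken as a third substituent at this place, on an aromatic carbon para to a large group, trifluoromethyl leaves the reading in this assay where bromo and nitro had it: the swap for bromo gives no separable step (a 1.0-fold higher number from compound 2 to compound 3 (0.00 log units; within the scatter)), and neither does the swap for nitro (a 1.3-fold higher number from compound 1 to compound 3 (0.11 log units; within the scatter)). Before compound 3, the only comparison at this place was a single pair, whereas now three groups stand within the scatter of one another, and no order among compounds 1, 2 and 3 can be drawn in this assay. Going from bromo to trifluoromethyl replaces one heavy atom with four, and that difference in count comes with no step beyond the scatter, but nothing at hand bears on why these numbers lie so close.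

What the three compounds leave open is whether this flat reading would hold for a group of another kind at the same place, such as an amine, a carboxylic acid or a longer chain. They also leave open whether changes elsewhere on the shared core would move the number in this assay any further.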